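Amide substituent changes and a morpholin-4-yl analogue

The source may hold more compounds than are shown below. What is called first, only, known or untested is meant among the compounds shown, and "the series" means these compounds.

Measured compounds:
compound 1 `COc1cc2nc(N3CCC(C(=O)NC4CCCC4)CC3)nc(N)c2cc1OC` gives 0.63 nM
compound 2 `COCCNC(=O)C1CCN(c2nc(N)c3cc(OC)c(OC)cc3n2)CC1` gives 1.13 nM
compound 3 `CCN(CC)C(=O)C1CCN(c2nc(N)c3cc(OC)c(OC)cc3n2)CC1` gives 1.11 nM

All three values come from an assay on isolated protein for displacement of a labelled ligand from Adrenergic receptor alpha-1 (Rattus norvegicus); a higher number here means a weaker inhibitor, a lower number a stronger inhibitor. Compound 3 stands second highest of the three numbers, yet its nearest neighbour is compound 2 at a 1.0-fold lower number from compound 2 to compound 3 (0.01 log units; within the scatter) and its furthest is compound 1 at a 1.8-fold higher number from compound 1 to compound 3 (0.25 log units; within the scatter), so the three sit within the scatter of one another.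

Compound 4 `COc1cc2nc(N3CCC(C(=O)N4CCOCC4)CC3)nc(N)c2cc1OC` is not yet measured. It differs from compound 3 by morpholin-4-yl in place of diethylamino on a carbonyl carbon. Within the data shown here, the steps that bear on this change are a 1.8-fold higher number from compound 1 to compound 3 (0.25 log units; within the scatter) and a 1.0-fold lower number from compound 2 to compound 3 (0.01 log units; within the scatter), both small: three different amide substituents on the same carbonyl carbon leave this assay essentially unmoved. For compound 4 the expected step is therefore a 1.0-fold lower number from compound 3 to compound 4 (0.00 log units; within the scatter), none beyond the scatter. Compound 4 is estimated at 1.1 nM, with a range from 0.5 nM to 2.5 nM.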

Compound 4, inhibition constant: 1.14 nM
The estimate for compound 4 lay 1.0-fold (0.02 log units) below the measured number; the measured number falls inside the stated range.
By their numbers in this assay, from the lowest: compounds 1, 3, 2 and 4 (each within the scatter of the next).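

Closing the amide substituent into a ring containing oxygen leaves the carbonyl position as flat as the open-chain groups did in this assay: there is a 1.0-fold higher number from compound 3 to compound 4 (0.01 log units; within the scatter) for morpholin-4-yl in place of diethylamino and a 1.0-fold higher number from compound 2 to compound 4 (0.00 log units; within the scatter) against (2-methoxyethyl)amino. Even against the cyclopentylamino amide, the step remains small, at a 1.8-fold higher number from compound 1 to compound 4 (0.26 log units; within the scatter). Nothing measured here explains this flatness.

Open, from the compounds shown here alone, is whether a substituent carrying a carboxylic acid, a basic amine or a much longer chain would move the number. The shown compounds also do not test replacement of the carbonyl itself.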